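Removing the acetyl group from compound 2

The source may report more compounds than this note shows. Statements on the series, on what has been measured and on what is new or still open speak of the compounds shown alone.

Values in a functional assay on NIH3T3 cells (Mus musculus) for inhibition, read by MTT assay, with a stated time of 72 h; on this read-out lower numbers stand for stronger inhibition and higher numbers for weaker inhibition:
Compound 1 `C=C1CC[C@H]2[C@@](C)(CC[C@@H](OC(C)=O)[C@@]2(C)C(=O)OCc2ccccc2)[C@@H]1CCC1=CCOC1=O`: 12900 nM
Compound 2 `C=C1CC[C@H]2[C@@](C)(CC[C@@H](OC(C)=O)[C@@]2(C)C(=O)OCc2ccccc2)[C@@H]1/C=C/C1=CCOC1=O`: 52700 nM
Compound 3 `C=C1CC[C@H]2[C@@](C)(CC[C@@H](OC(C)=O)[C@@]2(C)C(=O)OCc2ccccn2)[C@@H]1/C=C/C1=CCOC1=O`: 34900 nM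

Compound 2 shares the high end of these numbers with compound 3, as shown by a 1.5-fold lower number from compound 2 to compound 3 (0.18 log units; within the scatter). The gap on the other side is a 4.1-fold higher number from compound 1 to compound 2 (0.61 log units; beyond the scatter).

Compound 4 `C=C1CC[C@H]2[C@@](C)(CC[C@@H](O)[C@@]2(C)C(=O)OCc2ccccc2)[C@@H]1/C=C/C1=CCOC1=O` differs from compound 2 by hydrogen in place of acetyl on an oxygen on a saturated carbon, which is acetoxy to hydroxy. For the measured compounds named here, no measured step touches this place. The steps of a 4.1-fold higher number from compound 1 to compound 2 (0.61 log units; beyond the scatter) and a 1.5-fold lower number from compound 2 to compound 3 (0.18 log units; within the scatter) changed other parts of the structure, so they offer only a rough guide to size. No step beyond the scatter is firmly expected in this assay, and no direction is secure. The estimated step is a 1.3-fold lower number from compound 2 to compound 4 (0.12 log units; within the scatter). Compound 4 is expected at 40000 nM, with an estimated range of 15000 nM to 90000 nM.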

Compound 4, half-maximal inhibitory concentration: 13600 nM
Compound 4: the middle estimate sits 2.9-fold (0.47 log units) above what was measured; measured number below the stated range.
By their numbers in this assay, from the lowest: compounds 1 and 4 (each within the scatter of the next); then compounds 3 and 2 (each within the scatter of the next).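

In this assay, for the compounds shown here, acetoxy to hydroxy on the oxygen gives a clear change (a 3.9-fold lower number from compound 2 to compound 4 (0.59 log units; beyond the scatter)), so this position, untouched by the earlier steps, does influence the read-out. Loss of the acetyl group strengthens inhibition here rather than costing it, though only one pair shows this. Nothing available bears on the reason for this step.

From the compounds shown here alone, whether the same change holds alongside pyridin-2-yl or the saturated chain of compound 1 remains open. So does the effect of a methyl ether, a longer acyl chain or an amine at this position.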